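The source may hold more compounds than are shown below. What is called first, only, known or untested is meant among the compounds shown, and "the series" means these compounds.

Compound 1 `COc1cc(NC(C)CCCNC(=O)C2CCC3(CC2)OOC2(OO3)C3CC4CC(C3)CC2C4)c2nccc(Cl)c2c1`: > 50000000 nM
Compound 2 `COc1cc(NC(C)CCCNC(=O)C2CCC3(CC2)OOC2(OO3)C3CC4CC(C3)CC2C4)c2nccc(F)c2c1`: > 50000000 nM

Both entries come from a functional assay on Caco-2 cells (Homo sapiens) for cytotoxicity; on this read-out higher numbers stand for lower toxicity in this test and lower numbers for higher toxicity in this test. The entry for compound 1 is a limit, not a number. The entry for compound 2 is also a limit, not a number. Compound 2 therefore stands on (the limit of > 50000000 nM in this assay, at which 2 of the 2 values shown sit).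

Compound 3 `COc1cc(NC(C)CCCNC(=O)C2CCC3(CC2)OOC2(OO3)C3CC4CC(C3)CC2C4)c2nccc(Br)c2c1` has bromo in place of fluoro on an aromatic carbon, opposite the ring nitrogen: bromo in place of fluoro on an aromatic carbon.

Within the data shown here, the one measured step that bears on this change is a step that the two limits leave unreadable from compound 1 to compound 2, which involves the same aromatic carbon. It gives no size to carry over, so no step beyond the usual scatter is expected in this assay, in either direction, and another limit is the likeliest report. The expected step is a number no higher from compound 2 to compound 3 (the limit leaves the size open). For compound 3 the estimated value is 50000000 nM, with an expected range from 25000000 nM to 100000000 nM.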

Compound 3, half-maximal cytotoxic concentration: > 50000000 nM
Compound 3: a limit, no number; the forecaster's own chance of this, stated with the estimate: 85%; the middle value lies on the limit itself.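

No step can be read among compound 1, compound 2 and compound 3, as each entry in this assay is a limit rather than a number: the limit of > 50000000 nM in this assay, at which 3 of the 3 values shown sit.

The compounds shown leave open how the chloro, fluoro and bromo versions compare in this test.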